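This account rests on a few compounds, and the source may have more. Where it says the series, first, only, none or still open, it means among the compounds named here.

Four compounds share a common core and differ in two places. Compound 1 `CN1CCN(Cc2ccc(NC(=O)Nc3ccc4ncnc(Nc5cccc(C(F)(F)F)c5)c4c3)cc2)CC1` carries a 3-(trifluoromethyl)phenyl group on a nitrogen on an aromatic ring and a benzyl-linked piperazine on its urea. In a functional assay on A-431 cells (Homo sapiens) for antiproliferative activity, read by MTT assay, with a stated time of 72 h (a higher number here means a weaker inhibitor, a lower number a stronger inhibitor), compound 1 gives 2410 nM. Compound 2 `C[C@@H](Nc1ncnc2ccc(NC(=O)Nc3ccc(CN4CCN(C)CC4)cc3)cc12)c1ccccc1` keeps the same urea side but replaces the aryl group with a 1-phenylethyl group; in this assay compound 2 reaches only a limit, > 10000 nM. The change from compound 1 to compound 2 is 1-phenylethyl in place of 3-(trifluoromethyl)phenyl on a nitrogen on an aromatic ring and it gave an at least 4.1-fold higher number from compound 1 to compound 2 (0.61 log units; beyond the scatter); the size of that step is bounded by the limit of > 10000 nM in this assay, at which 2 of the 3 values shown sit.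

Compound 3 `CN1CCN(CCNC(=O)Nc2ccc3ncnc(Nc4cccc(C(F)(F)F)c4)c3c2)CC1` keeps the 3-(trifluoromethyl)phenyl group of compound 1 but carries a short chain to the piperazine instead of the benzyl link. In this assay compound 3 also gives only a limit, > 10000 nM. How the cores of compound 1 and compound 3 differ is not broken down here.

Compound 4 `C[C@@H](Nc1ncnc2ccc(NC(=O)NCCN3CCN(C)CC3)cc12)c1ccccc1` has not yet been measured in this assay. It differs from compound 3 by 1-phenylethyl in place of 3-(trifluoromethyl)phenyl on a nitrogen on an aromatic ring, the same change as that from compound 1 to compound 2, made at the same place. Since that change already weakened compound 1 to compound 2 by an at least 4.1-fold higher number from compound 1 to compound 2 (0.61 log units; beyond the scatter), and compound 3 itself starts at a limit of > 10000 nM, compound 4 is expected to sit at or beyond the same limit, with an estimated step that the limit leaves unreadable from compound 3 to compound 4. The expected value for compound 4 is 40000 nM, within a range of 12000 nM to 150000 nM.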

Compound 4, half-maximal inhibitory concentration: > 10000 nM
Compound 4 ended at the assay's limit; the forecaster's own chance of this, stated with the estimate: 90%; the middle value does not contradict the limit.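

In this assay compound 4 gives > 10000 nM, which is a limit and not a number. Compound 3 also stands at a limit, so no step can be read from compound 3 to compound 4: the limit of > 10000 nM in this assay, at which 3 of the 4 values shown sit.

The compounds shown leave open how far compound 3 and compound 4 lie past that limit, and whether 1-phenylethyl in place of 3-(trifluoromethyl)phenyl changes anything with the short chain.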